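This account rests on a few compounds, and the source may have more. Where it says the series, first, only, none or still open, it means among the compounds named here.

In a functional assay on A549 cells (Homo sapiens) for inhibition, read by sulforhodamine B assay, with a stated time of 48 h (a lower number here means a stronger inhibitor of growth, a higher number a weaker inhibitor of growth), two compounds have been measured so far. Compound 1 (`Cc1ccn2c(CN3CCCCC3)c(-c3ccccc3)nc2n1`) gives 4040 nM, while compound 2 (`CC(C)(C)c1nc2ncccn2c1CN1CCCCC1`) gives 330 nM. Compound 2 therefore has the lower of the two numbers, and the gap between them lies beyond the usual scatter. These two structures differ in more than one place, so their gap cannot be assigned to any single change.

Compound 3 (`Cc1ccn2c(CN3CCCCC3)c(C(C)(C)C)nc2n1`) comes from compound 2 through one small edit: methyl in place of hydrogen on an aromatic carbon. Among the compounds with values here, no measured pair isolates this edit. Compound 1 carries the same methyl and stands at 4040 nM, but it also differs from compound 3 elsewhere, so it offers only a weak hint of a higher number. The closest anchor is compound 2 at 330 nM. In this assay, a modest move toward a higher number is expected, possibly one that stays within the scatter. The expected change is a 1.5-fold higher number from compound 2 to compound 3 (0.16 log units; within the scatter). For compound 3, the estimated value is 480 nM, with an expected range of 150 nM to 1800 nM.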

Compound 3, concentration for 50% growth inhibition: 7390 nM
Compound 3: middle estimate off by 15-fold (1.19 log units), on the low side; measured number outside the range, above it.
By their numbers in this assay, from the lowest: compound 2; then compounds 1 and 3 (each within the scatter of the next).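

In this assay the added methyl on the aromatic carbon of the six-membered aromatic ring with 2 nitrogen is far from a minor edit: it gives a 22-fold higher number from compound 2 to compound 3 (1.35 log units; beyond the scatter) and so moves the compound a long way toward weaker growth inhibition. The earlier pair could not show this, since compound 1 and compound 2 differ in more than one place. Exchanging phenyl for tert-butyl on an aromatic carbon, with that methyl present, gives a 1.8-fold higher number from compound 1 to compound 3 (0.26 log units; within the scatter) and stays within the scatter, so this pair shows no readable difference between those two groups. No measurement shown here explains why the methyl matters so much in this pair.

Going by these compounds, it remains open whether a fluorine atom, a methoxy group or an ethyl group on the same carbon would read like hydrogen or like methyl. On these data alone, it is also open whether the methyl would have a similar effect with phenyl in place of tert-butyl, and whether any of this would hold with a morpholine ring in place of the piperidine-derived amine.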